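The source may report more compounds than this note shows. Statements on the series, on what has been measured and on what is new or still open speak of the compounds shown alone.

Measured so far in a functional assay on U-373MG ATCC cells (Homo sapiens) for inhibition, read by MTT assay, with a stated time of 72 h; on this read-out lower numbers stand for stronger inhibition and higher numbers for weaker inhibition:
compound 1 `CC1(C)CC(NC(=S)Nc2cccc(C#N)c2)c2cc(Br)ccc2O1`: 6000 nM
compound 2 `CC1(C)CC(NC(=S)Nc2cccc(C#N)c2)c2cc(F)ccc2O1`: 30000 nM
compound 3 `CC1(C)CC(NC(=O)Nc2ccccc2Cl)c2cc(Cl)ccc2O1`: 17000 nM

Compound 1 holds the lowest of the three numbers in this assay, and its gaps to the other two lie beyond the scatter. That makes it the natural reference for the next comparison.

The unmeasured compound 4 `CC1(C)CC(NC(=S)Nc2ccc(Cl)cc2)c2cc(Br)ccc2O1` keeps the core of compound 1 and exchanges only the aryl group: 4-chlorophenyl comes in place of 3-cyanophenyl on an amide-type nitrogen (4-chlorophenyl in place of 3-cyanophenyl on an amide-type nitrogen).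

One measured step is available, and it sits elsewhere in the molecule: a 5.0-fold higher number from compound 1 to compound 2 (0.70 log units; beyond the scatter), with fluoro in place of bromo on an aromatic carbon. It shows that a single exchange can move this read-out modestly, but it says nothing about the aryl group. Compound 1 differs from compound 3 in more than one place, so the value of compound 3 at 17000 nM gives no clean reading either. Going by the values given here, no measured pair isolates the change at hand, so the data give no direction for it. The expectation is therefore no step beyond the scatter, though a modest move either way would not surprise. The expected step is a 1.2-fold lower number from compound 1 to compound 4 (0.08 log units; within the scatter). For compound 4 the estimate is 5000 nM, with an expected range from 1500 nM to 20000 nM.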

Compound 4, half-maximal inhibitory concentration: 7000 nM
The estimate for compound 4 lay 1.4-fold (0.15 log units) below the measured number; measured number inside the range.
By their numbers in this assay, from the lowest: compounds 1 and 4 (each within the scatter of the next); then compounds 3 and 2 (each within the scatter of the next).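

In this assay, the aryl group on the amide-type nitrogen now has a direct reading with the bromo-bearing core held constant: a 1.2-fold higher number from compound 1 to compound 4 (0.07 log units; within the scatter), with 4-chlorophenyl in place of 3-cyanophenyl. Going by these compounds alone, this exchange replaces the nitrile-bearing aryl group with a chlorine-bearing one and leaves the number within the scatter, whereas the only other single exchange in the set, on an aromatic carbon, gives a 5.0-fold higher number from compound 1 to compound 2 (0.70 log units; beyond the scatter), beyond the scatter. No supporting data accompany these results, so the reason for either outcome remains unexplained.

The two aryl groups on the thiocarbonyl-linked nitrogen give only a narrow view of this position, leaving open whether a phenyl ring carrying an amine or a carboxylic acid, or a longer alkyl chain in place of the aryl group, would hold the number near that of compound 1. From the compounds shown here alone, the effect of carbonyl in place of thiocarbonyl also remains open, since compound 3 differs from compound 1 and compound 4 in more than one place and its step to either cannot be read.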